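The source may hold more compounds than are shown below. What is called first, only, known or untested is meant among the compounds shown, and "the series" means these compounds.

Among the measured compounds shown here, compound 2, with the structure `CC(C)NC(=O)N1CCN(C(=S)SCc2cn(Cc3ccc(F)cc3)nn2)CC1`, is the stronger of the two compounds measured so far in a functional assay on EC9706 cells (Homo sapiens) for cytotoxicity, read by MTT assay, with a stated time of 72 h; on this read-out higher numbers stand for weaker inhibition and lower numbers for stronger inhibition. In this assay compound 2 gives 12200 nM. For the measured compounds named here, its only neighbour, compound 1, has the structure `NC(=O)N1CCN(C(=S)SCc2cn(Cc3ccc(F)cc3)nn2)CC1` and in this assay compound 1 gives 62700 nM. The two differ at one point, and the step of a 5.1-fold lower number from compound 1 to compound 2 (0.71 log units; beyond the scatter) places compound 2 at the lower end of the pair.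

Compound 3, with the structure `CCN(C)C(=O)N1CCN(C(=S)SCc2cn(Cc3ccc(F)cc3)nn2)CC1`, has the same atoms as compound 2 but joins them differently: the change is ethyl(methyl)amino in place of isopropylamino on a carbonyl carbon. One hydrogen-bond donor leaves and none enters. Going by the values given here, no measured step covers this kind of rearrangement; the one step available, from compound 1 to compound 2, shows only that filling that same nitrogen with an alkyl group lowered the number, and compound 3 already carries such a group. With no direct guide, a small shift in this assay, not beyond the scatter, is expected, so the step for compound 3 is estimated as a 1.2-fold higher number from compound 2 to compound 3 (0.09 log units; within the scatter). For compound 3 the expected value is 15000 nM, with a range from 5000 nM to 45000 nM.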

Compound 3, half-maximal inhibitory concentration: 14300 nM
For compound 3 the middle estimate is 1.0-fold (0.02 log units) above the measured one; the range from low to high includes it.
By their numbers in this assay, from the lowest: compounds 2 and 3 (each within the scatter of the next); then compound 1.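

In this assay, rearranging the same atoms from isopropylamino to ethyl(methyl)amino on the carbonyl carbon gives a 1.2-fold higher number from compound 2 to compound 3 (0.07 log units; within the scatter), so among these compounds, losing the hydrogen on that nitrogen leaves the number within the usual scatter. Against the plain amino group of compound 1, the ethyl(methyl)amino group gives a 4.4-fold lower number from compound 1 to compound 3 (0.64 log units; beyond the scatter), which shows that the lower number seen with isopropylamino does not depend on that nitrogen keeping a hydrogen and is also reached with two alkyl groups in place of both hydrogens. Nothing available explains why these numbers fall as they do.

Isopropylamino and ethyl(methyl)amino hold the same atoms, so these compounds do not show how the number responds when the group on the carbonyl carbon grows or shrinks, as it might with a dimethylamino group or a longer chain such as hexyl. They also leave open whether a group of a different kind, such as a carboxylic acid or a free amine at the end of that chain, would be tolerated in this assay.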